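Compound 4: (propylcarbonyl)oxy in place of cyano

The source may report more compounds than this note shows. Statements on the series, on what has been measured and on what is new or still open speak of the compounds shown alone.

Compound 2 `C[S+]([O-])/C=C/c1cc(=O)c2cc(C#N)ccc2o1` gives in a functional assay on DLD-1 cells (Homo sapiens) for cytotoxicity, with a stated time of 48 h (a lower number here means a stronger inhibitor, a higher number a weaker inhibitor), only a limit, > 10000 nM. For the measured compounds named here, at this limit, (the limit of > 10000 nM in this assay, at which 1 of the 3 values shown sits), compound 2 is the sole member. The two compounds with a number, compound 1 `COc1cccc2c(=O)cc(/C=C/[S+](C)[O-])oc12` with 9000 nM and compound 3 `Cc1cccc2c(=O)cc(/C=C/[S+](C)[O-])oc12` with 6800 nM, lie within the scatter of each other, as the step of a 1.3-fold lower number from compound 1 to compound 3 (0.12 log units; within the scatter) shows. Compound 4 `CCCC(=O)Oc1ccc2oc(/C=C/[S+](C)[O-])cc(=O)c2c1` differs from compound 2 by (propylcarbonyl)oxy in place of cyano on an aromatic carbon. Going by the values given here, no measured step touches this change: the only step measured, from compound 1 to compound 3, exchanges other groups at another place and stays within the scatter, so it offers no direction. The three values together place the series in a narrow band, and compound 2 is known only as a limit. The step of an at least 1.2-fold lower number from compound 2 to compound 4 (0.09 log units; that floor lies within the scatter) is therefore expected to be small, in either direction. Compound 4 is estimated at 8000 nM in this assay, between 3000 nM and 20000 nM, with a real chance that this assay again returns only a limit.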

Compound 4, half-maximal inhibitory concentration: 8700 nM
Beside the measured number, compound 4's estimate is 1.1-fold (0.04 log units) below it, within the range that was stated.
By their numbers in this assay, from the lowest: compounds 3, 4 and 1 (each within the scatter of the next). At a limit, above all of these: compound 2.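

For the compounds shown here, replacing cyano with (propylcarbonyl)oxy on this aromatic carbon gives the first number at this place in this assay, and the change reads as an at least 1.1-fold lower number from compound 2 to compound 4 (0.06 log units; that floor lies within the scatter). That step is a floor and not a size, so the true gap between the two groups may be larger than it shows, and no direction beyond the scatter is established for this change. Compound 2 is held only as a limit of the assay: the limit of > 10000 nM in this assay, at which 1 of the 4 values shown sits.

Still open, on these data alone, is what an amine or a hydroxyl on this aromatic carbon would give in this assay, and whether a longer chain in place of the propyl part would move the number beyond the scatter. The compounds shown also leave open how methoxy or methyl would compare with (propylcarbonyl)oxy at this same place.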